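Exocyclic double-bond geometry within a semicarbazone series

This account rests on a few compounds, and the source may have more. Where it says the series, first, only, none or still open, it means among the compounds named here.

Measured so far:
compound 1 `O=C(O)CCC/C=C1\C[C@H]2C[C@@H](O)[C@H](/C=N/NC(=O)Nc3ccccc3)[C@H]2C1` gives 1700 nM
compound 2 `O=C(O)CCC/C=C1/C[C@H]2C[C@@H](O)[C@H](/C=N/NC(=O)Nc3ccc([N+](=O)[O-])cc3)[C@H]2C1` gives 50 nM

In a functional assay on a cell-free system (plasma) for agonist activity at thromboxane A2 receptor (Homo sapiens) (on this read-out lower numbers stand for stronger inhibition and higher numbers for weaker inhibition), compound 2 stands with the lowest of the two numbers; compound 1 gives a higher number, and the gap lies beyond the scatter, but the two compounds differ in more than one place, so no single-change step can be read from them. Compound 3 `O=C(O)CCC/C=C1\C[C@H]2C[C@@H](O)[C@H](/C=N/NC(=O)Nc3ccc([N+](=O)[O-])cc3)[C@H]2C1` has the same atoms and bonds as compound 2 and differs only in configuration as drawn: the two compounds have the same atoms and bonds and differ only in configuration as drawn: 1 of 6 stereo elements differ; a double bond is drawn Z in compound 2 and E in compound 3. Within the data shown here, no measured pair isolates this geometric change, so the expected step is modest and toward a higher number: a 3.0-fold higher number from compound 2 to compound 3 (0.48 log units; beyond the scatter). Compound 3 is estimated at 150 nM, in the range 40 nM to 600 nM.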

Compound 3, half-maximal inhibitory concentration: 60 nM
Compound 3: middle estimate off by 2.5-fold (0.40 log units), on the high side, and the stated range covers the measured number.
By their numbers in this assay, from the lowest: compounds 2 and 3 (each within the scatter of the next); then compound 1.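

In this assay, the geometry of the exocyclic double bond does not separate the pair, with a 1.2-fold higher number from compound 2 to compound 3 (0.08 log units; within the scatter), and this comparison reads on that bond alone: the fact that compounds 2 and 3 differ only in the configuration as drawn. The aromatic substituent instead carries the large step, a 28-fold lower number from compound 1 to compound 3 (1.45 log units; beyond the scatter), with nitro in place of hydrogen on an aromatic carbon. This makes that aromatic position, not the double-bond geometry, the place where the number moves in these compounds.

Open, as far as these compounds go, is whether an amine or a nitrile at that aromatic carbon would give a similar step. Also open, from the compounds shown here alone, is whether the double-bond geometry remains without a step beyond the scatter when hydrogen replaces nitro.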